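The source may report more compounds than this note shows. Statements on the series, on what has been measured and on what is new or still open speak of the compounds shown alone.

Compound 1 `CC#C[C@H]1CN(S(=O)(=O)c2ccc(N)nc2)CCN1c1ccc(S(=O)(=O)NCC2CC2)cc1` is the starting point of this set. In an assay on cells (Hepatocyte) for inhibition of glucokinase regulatory protein (Mus musculus), with stated times of 20 min and 40 min (a higher number here means that more compound is needed for the effect, a lower number that less compound is needed), compound 1 gives 271 nM, the lowest of the two numbers measured here. Compound 3 `CC#C[C@H]1CN(S(=O)(=O)c2ccc(N)nc2)CCN1c1ncc(C(O)(C(F)(F)F)C(F)(F)F)cn1` gives 2200 nM in this assay, a gap from compound 1 that lies beyond the usual scatter of repeated measurements. Compound 2 `CC#C[C@H]1CN(S(=O)(=O)c2ccc(N)nc2)CCN1c1ncc(C(C)(O)C(F)(F)F)s1` is reported in this assay as > 12500 nM, which is a limit of the assay rather than a number (the limit of > 12500 nM in this assay, at which 1 of the 3 values shown sits).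

Compound 4 `CC#C[C@H]1CN(S(=O)(=O)c2ccc(N)nc2)CCN1c1ccc(C(C)=O)cc1` has not yet been measured. It differs from compound 1 in one place: acetyl in place of (cyclopropylmethyl)sulfamoyl on an aromatic carbon. For the measured compounds named here, no measured pair in this set makes the same exchange, so the size of the step rests on expectation alone. The hydrogen-bond donor that leaves with the (cyclopropylmethyl)sulfamoyl group is not replaced, and the expected step of a 2.8-fold higher number from compound 1 to compound 4 (0.44 log units; beyond the scatter) in this assay is a modest loss, beyond the scatter but far short of the gap between compound 1 and compound 3. For compound 4 the estimate in this assay is 750 nM, with a likely range from 250 nM to 2500 nM.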

Compound 4, half-maximal effective concentration: > 12500 nM
Compound 4: a limit, no number; the forecaster's own chance of this, stated with the estimate: 10%; at least 16-fold (1.22 log units) between middle value and limit.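

The core of compound 1 stays the same in this exchange, so an at least 46-fold higher number from compound 1 to compound 4 (1.66 log units; beyond the scatter) belongs to this one place, the aromatic carbon para to a large group, and shows that what sits there can decide whether any effect is read at all. In this assay, on these data alone, compound 4 gives > 12500 nM, which is a limit of the assay and not a number, so the true size of the step stays unknown. Compound 4 therefore joins the compounds that give no number in this set: the limit of > 12500 nM in this assay, at which 2 of the 4 values shown sit.

The exchange removes the three-membered ring, the hydrogen-bond donor and several heavy atoms together, and the compounds shown do not tell which of these matters. As far as these compounds go, how a methylsulfonyl group or a carboxylic acid would fare at this carbon also remains open.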